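This account rests on a few compounds, and the source may have more. Where it says the series, first, only, none or still open, it means among the compounds named here.

Measured in a functional assay on Jurkat cells (Homo sapiens) for cytotoxicity, read by luminescence and CellTiter-Glo, with a stated time of 3 days; a lower number here means a stronger inhibitor, a higher number a weaker inhibitor:
- compound 1 `O=C(Nc1cc(C(F)(F)F)cc(C(F)(F)F)c1)c1cc(Br)c(-c2ccccc2)cc1O`: 680 nM
- compound 2 `O=C(Nc1ccc(C(F)(F)F)cc1)c1cc(Cl)ccc1O`: 710 nM
- compound 3 `O=C(Nc1cc(C(F)(F)F)cc(C(F)(F)F)c1)c1ccc(-c2ccccc2)cc1O`: 1240 nM

At 1240 nM, compound 3 lies within the scatter of both compound 1 and compound 2, so the three values do not separate. Compound 4 `O=C(Nc1cc(C(F)(F)F)cc(C(F)(F)F)c1)c1ccc(Cl)cc1O` carries chloro in place of phenyl on an aromatic carbon.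

For the measured compounds named here, no measured step makes this exchange. Going by the values given here, the only step available, a 1.8-fold higher number from compound 1 to compound 3 (0.26 log units; within the scatter), is hydrogen in place of bromo, which stays within the scatter and leaves the phenyl untouched. It bears on the change only loosely. Compound 2 also carries a chloro and gives 710 nM, but it differs from compound 4 in more than one place, so it offers only a rough guide. With all three values this close, no shift beyond the scatter is expected in this assay, although the data leave the effect of losing the phenyl untested. The estimated step is a 1.4-fold lower number from compound 3 to compound 4 (0.14 log units; within the scatter). Compound 4 is estimated at 900 nM, with an expected range from 350 nM to 2300 nM.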

Compound 4, half-maximal inhibitory concentration: 570 nM
Compound 4: middle estimate off by 1.6-fold (0.20 log units), on the high side; low and high end bracket the measured number.
By their numbers in this assay, from the lowest: compounds 4, 1, 2 and 3 (each within the scatter of the next, the first and the last beyond it).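

In this assay the exchange of phenyl for chloro on this aromatic carbon, meta to a hydroxy group and para to a large group, gives a 2.2-fold lower number from compound 3 to compound 4 (0.34 log units; beyond the scatter) and is the first step among the compounds shown to pass beyond the scatter. The earlier step, from bromo to hydrogen, left the phenyl in place and stayed within the scatter, so only this result shows that the phenyl ring can leave this position without any loss in this assay, with a single chlorine standing in its place. Nothing at hand explains why the number falls with this exchange.

As far as these compounds go, only phenyl and chloro can be compared at this position, so it remains open whether the gain belongs to chloro itself or comes simply with the loss of the phenyl. From the compounds shown here alone, how a methoxy group, an amine or a carboxylic acid would behave on the same carbon also stays open.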